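The source may report more compounds than this note shows. Statements on the series, on what has been measured and on what is new or still open speak of the compounds shown alone.

Working notes on the series. In an assay on membranes from brain for binding affinity to adenosine receptor A1 (Rattus norvegicus), read by radioligand binding, tested at 20 uM (a higher number here means more inhibition at the concentration tested (going by the name of the read-out), a lower number less inhibition), compound 1 `Cn1c(=O)[nH]c2c(cnn2-c2ccccc2[N+](=O)[O-])c1=N` gives 5%. In this assay compound 3 `Cn1c(=O)[nH]c2c(cnn2-c2ccccc2F)c1=N` gives 8%, and in this assay compound 2 `CCCn1c(=O)[nH]c2c(cnn2-c2cccc(Cl)c2)c1=N` gives 68%. On these three numbers compound 3 stands second highest; its nearest neighbour is compound 1, within the scatter, while compound 2 lies beyond the scatter above it. Compound 2 differs from compound 3 in more than one place, so its gap to compound 3 cannot be traced to a single change. Going by the values given here, the only step measured in one place is a number 3 percentage points higher from compound 1 to compound 3 (within the scatter), a change within the scatter, which shows that swapping one small substituent for another on that aromatic carbon left this assay essentially unmoved.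

Compound 4 `Cn1c(=O)[nH]c2c(cnn2-c2ccccc2)c1=N` is not yet measured. Its difference from compound 3 is hydrogen in place of fluoro on an aromatic carbon. The step from compound 1 to compound 3 is the only one that bears on this change, and it was within the scatter, so a step within the scatter is expected here too, with no clear direction: no change at the digits printed from compound 3 to compound 4 (within the scatter). Compound 4 is accordingly estimated at 8% in this assay, within a range from 0% to 22%.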

Compound 4, a percentage reported as inhibition, at one concentration (the size of the read-out at that concentration, not a potency): 30%
Compound 4: the middle estimate sits 22 percentage points below what was measured; the measured number lies above the stated range.
By their numbers in this assay, from the lowest: compounds 1 and 3 (each within the scatter of the next); then compound 4; then compound 2.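

On an aromatic carbon ortho to a large group, the ring carrying hydrogen separates from both substituted rings in this assay: a number 22 percentage points higher from compound 3 to compound 4 (beyond the scatter), and a number 25 percentage points higher from compound 1 to compound 4 (beyond the scatter). The earlier step between fluoro and nitro suggested a position indifferent to its substituent, but that held only between those two groups; replacing either with hydrogen moves the number beyond the scatter, so this position does respond to change. Nothing available here explains the rise.

On these data alone, whether an amine or a methoxy group at this place would read like hydrogen or like fluoro and nitro remains open. Also open, as far as these compounds go, is whether the step from fluoro to hydrogen would keep its size on a core carrying a propyl chain, as compound 2 does.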